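A methoxyphenyl in place of the thiophene on the alkene

The compounds below may be only part of what the source reports. "The series", "measured", "known", "first", "only" and "open" are said of these compounds alone.

Among the compounds with values here, compound 3 `Cc1ccsc1/C=C(/SCc1ccc(Cl)cc1)C(=O)c1ccc(Cl)cc1` holds the highest of the three numbers measured so far: in a functional assay on DU-145 cells (Homo sapiens) for inhibition, read by trypan blue exclusion, with a stated time of 96 h (on this read-out higher numbers stand for weaker inhibition of growth and lower numbers for stronger inhibition of growth), compound 3 gives 50000 nM. Nearest to it is compound 1 `Cc1ccsc1/C=C(/SCc1ccc(Cl)cc1)C(=O)c1ccc(Br)cc1`, which in this assay gives 25000 nM; the step of a 2.0-fold higher number from compound 1 to compound 3 (0.30 log units; within the scatter) lies within the scatter, so the two are not told apart. Furthest from it is compound 2 `O=C(/C(=C\c1ccc(Br)cc1)SCc1ccc(Cl)cc1)c1ccc(Cl)cc1`, which in this assay gives 1000 nM. The move to compound 4 `COc1ccc(/C=C(/SCc2ccc(Cl)cc2)C(=O)c2ccc(Cl)cc2)cc1` is 4-methoxyphenyl in place of 3-methylthiophen-2-yl on a double-bonded chain carbon bound to a double-bonded chain carbon. Within the data shown here, the step that bears on it is a 50-fold higher number from compound 2 to compound 3 (1.70 log units; beyond the scatter), which went with a 3-methylthiophen-2-yl taking the place of a 4-bromophenyl on the double-bonded chain carbon; the change to compound 4 runs the other way, putting a six-membered aromatic ring of carbon only back into that place, though as a 4-methoxyphenyl rather than a 4-bromophenyl, and no measured pair shows what that difference does. A large drop in the number, back towards compound 2, is therefore expected, its size uncertain: the expected step is a 25-fold lower number from compound 3 to compound 4 (1.40 log units; beyond the scatter). For compound 4 the estimate in this assay is 2000 nM, with a range from 500 nM to 15000 nM.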

Compound 4, concentration for 50% growth inhibition: 10000 nM
For compound 4 the middle estimate is 5.0-fold (0.70 log units) below the measured one; low and high end bracket the measured number.
By their numbers in this assay, from the lowest: compound 2; then compound 4; then compounds 1 and 3 (each within the scatter of the next).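

In this assay the 4-methoxyphenyl on the double-bonded chain carbon gives a 5.0-fold lower number from compound 3 to compound 4 (0.70 log units; beyond the scatter) and so recovers only part of the large step seen earlier, a 50-fold higher number from compound 2 to compound 3 (1.70 log units; beyond the scatter) in the opposite sense. A six-membered aromatic ring of carbon only is therefore not enough at this position to reach the low number of compound 2, since the group on that ring also counts: changing that group alone gives a 10-fold higher number from compound 2 to compound 4 (1.00 log units; beyond the scatter) and the change lies beyond the scatter. Nothing available here explains why bromo and methoxy part in this way.

Whether an unsubstituted phenyl or a 4-aminophenyl at this position would fall nearer compound 2 or compound 4 stays open, so the compounds shown do not tell whether bromo is special or methoxy merely the poorer of two groups. Also open, going by these compounds, is whether chloro in place of bromo on the other aromatic ring, which gave a 2.0-fold higher number from compound 1 to compound 3 (0.30 log units; within the scatter) with the 3-methylthiophen-2-yl in place, would stay as small with a 4-methoxyphenyl there.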